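Methoxy for phenyl on the aryl ketone terminus

The compounds below may be only part of what the source reports. "The series", "measured", "known", "first", "only" and "open" are said of these compounds alone.

In a functional assay on RPMI-8226 cells (Homo sapiens) for inhibition, read by sulforhodamine B assay, with a stated time of 48 h, tested at 10 uM (on this read-out higher numbers stand for more inhibition of growth at the one concentration tested and lower numbers for less inhibition of growth), compound 1 `CCOC(=O)c1ccc(Nc2ccnc(SCC(=O)c3ccc([N+](=O)[O-])cc3)n2)cc1` gives 54%, compound 2 `CCOC(=O)c1ccc(Nc2ccnc(SCC(=O)c3ccc(C#N)cc3)n2)cc1` gives 80% and compound 3 `CC(=O)c1cccc(Nc2ccnc(SCC(=O)c3ccc(-c4ccccc4)cc3)n2)c1` gives 34%. Compound 3 is the lowest of the three, compound 1 nearest and compound 2 furthest, both beyond the scatter. Within the data shown here, the only step between close neighbours is a number 26 percentage points higher from compound 1 to compound 2 (beyond the scatter), a cyano in place of nitro on an aromatic carbon. Compound 4 `COc1ccc(C(=O)CSc2nccc(Nc3cccc(C(C)=O)c3)n2)cc1` differs from compound 3 by methoxy in place of phenyl on an aromatic carbon, para to a large group. Among the measured compounds shown here, no measured step swaps these two groups; the step from compound 1 to compound 2 shows only that a change at this position can move the number beyond the scatter. For compound 4 the expected step is therefore a number 6 percentage points higher from compound 3 to compound 4 (within the scatter), nothing beyond the scatter. Compound 4 is estimated at 40%, in a range from 15% to 65%.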

Compound 4, percent growth inhibition at one concentration: 42%
Compound 4: the middle estimate sits 2 percentage points below what was measured; the measured number falls inside the stated range.
By their numbers in this assay, from the lowest: compounds 3 and 4 (each within the scatter of the next); then compound 1; then compound 2.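

Methoxy in place of phenyl on the aromatic carbon para to a large group gives a number 8 percentage points higher from compound 3 to compound 4 (within the scatter) in this assay. The position thus tolerates losing a six-membered aromatic ring of carbon only without a shift beyond the scatter, so a change here need not move the number as the cyano-for-nitro step did. No measurement on hand accounts for this result. Going by these compounds, whether an amine, a carboxylic acid or a longer chain at this position would move the number remains open. So does whether methoxy would behave alike on the core of compound 2.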